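Working notes: from compound 3 to compound 4

A few compounds are considered here, and "the series" means these few. Any claim that something is new, unique, unknown or untested is made for them only; others in the source may bear on it.

Compound 1 `COc1ccc(F)cc1-c1ccnc2[nH]c(C3=CCN([C@H]4CC[C@@H](C(=O)O)CC4)CC3)cc12` gives 84%
Compound 2 `COc1ccc(F)cc1-c1c(F)cnc2[nH]c(C3=CCN([C@H]4CC[C@H](C(=O)O)CC4)CC3)cc12` gives 89.4%
Compound 3 `COc1ccc(F)cc1-c1c(F)cnc2[nH]c(C3=CCN([C@H]4CC[C@@H](C(=O)O)CC4)CC3)cc12` gives 90.1%
Compound 4 `COc1ccc(F)cc1-c1c(F)cnc2[nH]c(C3=CCN([C@H]4CC[C@H](CC(=O)O)CC4)CC3)cc12` is not yet measured

In an ADME assay on a cell-free system (plasma, Rattus norvegicus) for protein binding, compound 3 stands at 90.1% and lies within the scatter of both other measured compounds. The fluoro for hydrogen change gives a 1.6-fold lower unbound fraction from compound 1 to compound 3 (0.21 log units; within the scatter) and the inversion of configuration gives a 1.1-fold lower unbound fraction from compound 2 to compound 3 (0.03 log units; within the scatter) in the same read-out. The next change is 4-(carboxymethyl)cyclohexyl in place of 4-carboxycyclohexyl on an amine nitrogen in a ring with 4-(carboxymethyl)cyclohexyl in place of 4-carboxycyclohexyl on an amine nitrogen in a ring. Neither measured step alters this group, so both bear on the change only loosely. They show how little this read-out has moved so far, including for the pair covered by the fact that compounds 2 and 3 differ only in the configuration as drawn in this small set. No step beyond the scatter is expected, and the estimated change is a 1.0-fold higher unbound fraction from compound 3 to compound 4 (0.00 log units; within the scatter) with no firm direction. For compound 4 the estimate is 90% with an expected range from 83% to 95% in this assay once measured.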

Compound 4, plasma protein binding: 91.8%
Estimate against measurement, compound 4: 1.2-fold (0.09 log units) (unbound fraction) above, and the stated range covers the measured number.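

This is the first change shown at the group on the amine nitrogen in a ring, and in this assay 4-(carboxymethyl)cyclohexyl in place of 4-carboxycyclohexyl gives a 1.2-fold lower unbound fraction from compound 3 to compound 4 (0.08 log units; within the scatter). Read as carboxymethyl in place of carboxy on a saturated ring carbon, the change gives a 1.3-fold lower unbound fraction from compound 2 to compound 4 (0.11 log units; within the scatter). The change can thus be read against two carboxylic acid compounds, and neither step leaves the scatter, so this position accepts the extra carbon without a resolved shift in this read-out: the fact that compounds 2 and 3 differ only in the configuration as drawn

Open, on these data alone, is whether a longer chain ending in a carboxylic acid, or an amide or amine in place of the acid, would give a step beyond the scatter at this position. Also open, as far as these compounds go, is whether the 4-(carboxymethyl)cyclohexyl group with inverted configuration, or on the core of compound 1, would stay within the scatter of compound 4.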